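A Benzyl Swap Where Three Limits Sit

A few compounds are considered here, and "the series" means these few. Any claim that something is new, unique, unknown or untested is made for them only; others in the source may bear on it.

Compound 3 `COC(=O)[C@H](CCSC)NC(=O)c1ccc(NCc2cncn2Cc2ccc(C#N)cc2)cc1-c1ccccc1` stands in a functional assay on NIH3T3 cells (Mus musculus) (a higher number here means that more compound is needed for the effect, a lower number that less compound is needed), only at a limit: compound 3 gives > 10 uM. Compound 1 `COC(=O)[C@H](CCSC)NC(=O)c1ccc(NCc2cncn2Cc2ccc(C)cc2)cc1-c1ccccc1` likewise is reported in this assay only as the limit > 10 uM. Compound 2 `COC(=O)[C@H](CCSC)NC(=O)c1ccc(NCc2cncn2Cc2ccccc2C)cc1-c1ccccc1` too reaches only the limit > 10 uM in this assay. The steps a step that the two limits leave unreadable from compound 1 to compound 2, a step that the two limits leave unreadable from compound 1 to compound 3 and a step that the two limits leave unreadable from compound 2 to compound 3 therefore stay unreadable, since (the limit of > 10 uM in this assay, at which 3 of the 3 values shown sit). Compound 4 `COC(=O)[C@H](CCSC)NC(=O)c1ccc(NCc2cncn2Cc2ccccc2Cl)cc1-c1ccccc1` differs from compound 3 by 2-chlorophenyl in place of 4-cyanophenyl on a saturated chain carbon bound to an aromatic nitrogen. For the measured compounds named here, none of the measured steps gives a size to lean on, so no direction is expected; the expected step is a step that the limit leaves unreadable from compound 3 to compound 4. Compound 4 is estimated at 20 uM in this assay, with a range from 7 uM to 60 uM, and is expected most likely to be reported again only as a limit.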

Compound 4, concentration for half-maximal effect: > 10 uM
Compound 4 ended at the assay's limit; the forecaster's own chance of this, stated with the estimate: 80%; the middle value is on the limit's open side.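

Compound 4 joins compound 1, compound 2 and compound 3 at the limit, so none of its steps to them can be read: the limit of > 10 uM in this assay, at which 4 of the 4 values shown sit. The compounds shown leave open whether these benzyl groups differ at all in this assay.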